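The compounds below may be only part of what the source reports. "The series", "measured", "known", "first", "only" and "open" are said of these compounds alone.

Values so far in a functional assay on MDA-MB-231 cells (Homo sapiens) for cytotoxicity, read by MTT assay, with a stated time of 72 h; on this read-out lower numbers stand for stronger inhibition and higher numbers for weaker inhibition 
- compound 1 `CN(C)CCCCCn1c2c(c3ccccc31)C(=O)c1c[n+]([O-])c3ccccc3c1C2=O` gives 240 nM 
- compound 2 `O=C1c2c[n+]([O-])c3ccccc3c2C(=O)c2c1c1ccccc1n2CCCCn1ccnc1` gives 210 nM 
- compound 3 `O=C1c2c[n+]([O-])c3ccccc3c2C(=O)c2c1c1ccccc1n2Cc1cn(C[C@H](O)CO)nn1` gives 1310 nM 

Compound 3 holds the highest number of the three, and its gaps to both others lie beyond the scatter. Next in line is compound 4 `CN1CCN(CCCCn2c3c(c4ccccc42)C(=O)c2c[n+]([O-])c4ccccc4c2C3=O)CC1` with this change: 3-(4-methylpiperazin-1-yl)propyl in place of 1-(2,3-dihydroxypropyl)-1H-1,2,3-triazol-4-yl on a saturated chain carbon bound to an aromatic nitrogen that is, 3-(4-methylpiperazin-1-yl)propyl in place of 1-(2,3-dihydroxypropyl)-1H-1,2,3-triazol-4-yl on a saturated chain carbon bound to an aromatic nitrogen.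

The triazolyl group came in through two measured steps of modest and similar size: a 5.5-fold higher number from compound 1 to compound 3 (0.74 log units; beyond the scatter) and a 6.2-fold higher number from compound 2 to compound 3 (0.80 log units; beyond the scatter). The two chains it replaced there differ little in effect: a 1.1-fold lower number from compound 1 to compound 2 (0.06 log units; within the scatter). Going by the values given here, no measured compound carries the methylpiperazinyl group, so the reading is by analogy only, with compound 4 taken to resemble the two compounds on the low side.

A drop of similar size is therefore expected, estimated as a 5.2-fold lower number from compound 3 to compound 4 (0.72 log units; beyond the scatter) in this assay. For compound 4 the estimated value is 250 nM with an expected range from 100 nM to 650 nM as its bounds.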

Compound 4, half-maximal inhibitory concentration: 110 nM
Estimate against measurement, compound 4: 2.3-fold (0.36 log units) above, within the range that was stated.
By their numbers in this assay, from the lowest: compounds 4, 2 and 1 (each within the scatter of the next, the first and the last beyond it); then compound 3.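

In this assay, going by these compounds alone, the position on a saturated chain carbon bound to an aromatic nitrogen now shows its largest step so far, with 3-(4-methylpiperazin-1-yl)propyl replacing 1-(2,3-dihydroxypropyl)-1H-1,2,3-triazol-4-yl (a 12-fold lower number from compound 3 to compound 4 (1.08 log units; beyond the scatter)). Among the basic-looking chain ends, 4-methylpiperazin-1-yl cannot be told from 1H-imidazol-1-yl (a 1.9-fold lower number from compound 2 to compound 4 (0.28 log units; within the scatter)), while it only just separates from (dimethylamino)methyl (a 2.2-fold lower number from compound 1 to compound 4 (0.34 log units; beyond the scatter)), so the change of chain end at this length matters far less than the change to the triazolyl group. No measurement at hand accounts for any of these steps.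

As far as these compounds go, it remains open whether a morpholine or a carboxylic acid at the end of the same chain would keep the low numbers. A triazole carrying a simple methyl in place of 2,3-dihydroxypropyl would show whether the high number of compound 3 follows the ring or the diol.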